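Trifluoromethyl for Chloro on Two Related Cores

The source may hold more compounds than are shown below. What is called first, only, known or untested is meant among the compounds shown, and "the series" means these compounds.

Compound 1, `O=C(/C=C\Nc1ccc(Cl)cc1)c1cn(-c2ccccc2)nc1-c1ccc(F)cc1`: 8900 nM
Compound 2, `O=C(/C=C\Nc1ccc(C(F)(F)F)cc1)c1cn(-c2ccccc2)nc1-c1ccc(F)cc1`: > 50000 nM
Compound 3, `COc1cc(-c2nn(-c3ccccc3)cc2C(=O)/C=C\Nc2ccc(Cl)cc2)cc(OC)c1OC`: 3210 nM

These were measured in a functional assay on U-87MG ATCC cells (Homo sapiens) for antiproliferative activity, read by MTT assay, with a stated time of 48 h; on this read-out lower numbers stand for stronger inhibition and higher numbers for weaker inhibition. For compound 2 the result is only a limit, > 50000 nM, not a number. The change from compound 1 to compound 2 is trifluoromethyl in place of chloro on an aromatic carbon, and it brought an at least 5.6-fold higher number from compound 1 to compound 2 (0.74 log units; beyond the scatter). How the core of compound 3 differs from the core of compound 1 is not broken down here. Compound 4, `COc1cc(-c2nn(-c3ccccc3)cc2C(=O)/C=C\Nc2ccc(C(F)(F)F)cc2)cc(OC)c1OC`, is not yet measured; it differs from compound 3 by trifluoromethyl in place of chloro on an aromatic carbon, the same change in the same place. Since the earlier step ran up to the limit of > 50000 nM in this assay, at which 1 of the 3 values shown sits, the step from compound 3 to compound 4 is expected to be of similar size, a 7.8-fold higher number from compound 3 to compound 4 (0.89 log units; beyond the scatter). Compound 4 is therefore estimated at 25000 nM, between 8000 nM and 70000 nM, with a fair chance that only a limit is reported.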

Compound 4, half-maximal inhibitory concentration: > 50000 nM
Compound 4: a limit, no number; the forecaster's own chance of this, stated with the estimate: 35%; middle value at least 2.0-fold (0.30 log units) from the limit.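

Trifluoromethyl in place of chloro gave an at least 15-fold higher number from compound 3 to compound 4 (1.19 log units; beyond the scatter) in this assay, so the change ran in the same direction on the core of compound 3 as on the core of compound 1. Set side by side, the two steps agree in direction, but their sizes cannot be told apart: the same change on two cores in this assay, an at least 5.6-fold higher number (0.74 log units; beyond the scatter) from compound 1 to compound 2 and an at least 15-fold higher number (1.19 log units; beyond the scatter) from compound 3 to compound 4; the limit leaves it open whether they differ

The result for compound 4, > 50000 nM, is a limit and not a number, and the step between compound 2 and compound 4 cannot be read, as both results are limits.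

Still open, on these data alone, is how a nitrile or an amine on the same aromatic carbon would compare with chloro. Also open, as far as these compounds go, is whether the change behaves the same way on any core beyond these two.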